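This account rests on a few compounds, and the source may have more. Where it says the series, first, only, none or still open, it means among the compounds named here.

Compound 1, `Nc1cc(OCc2ccccc2-n2cccn2)c2nn[nH]c2n1`, in an assay for inhibition of Myeloperoxidase (Homo sapiens), read by Amplex Red, with stated times of 10 min and 15 min (on this read-out lower numbers stand for stronger inhibition and higher numbers for weaker inhibition), gives 26 nM.
Compound 2, `Nc1cc(OCc2cccc(Cl)c2)c2nn[nH]c2n1`, in this assay gives 21 nM.

Compound 2 has the lower of the two numbers, and compound 1 is its nearest neighbour with a slightly higher number, yet the two values lie within the scatter of repeated measurements, so neither can be called the more potent. Compound 3, `Cn1cc(-c2cccc(COc3cc(N)nc4[nH]nnc34)c2)cn1`, has not yet been measured. It differs from compound 2 in one place: 1-methyl-1H-pyrazol-4-yl in place of chloro on an aromatic carbon. For the measured compounds named here, no pair of measured compounds shares this exchange, so the size of the step cannot be read from a measured step. Both measured compounds carry differing groups on the same part of the shared core and give close numbers, which suggests that varied groups are tolerated there. The step from compound 2 to compound 3 is expected to stay within the scatter, a 1.4-fold higher number from compound 2 to compound 3 (0.15 log units; within the scatter). For compound 3 the expected value is 30 nM, with a range from 8 nM to 120 nM.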

Compound 3, half-maximal inhibitory concentration: 78 nM
For compound 3 the middle estimate is 2.6-fold (0.41 log units) below the measured one, within the range that was stated.
By their numbers in this assay, from the lowest: compounds 2 and 1 (each within the scatter of the next); then compound 3.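

Exchanging chloro for 1-methyl-1H-pyrazol-4-yl on this aromatic carbon weakens inhibition in this assay, with a 3.7-fold higher number from compound 2 to compound 3 (0.57 log units; beyond the scatter), a modest but real step. For the compounds shown here, this single exchange shows that the position does not accept every group equally, something that the close values of the earlier compounds did not reveal, although compound 3 still gives 78 nM with a group of six heavy atoms in place of one. No measurement shown here explains the loss.

The compounds shown cannot separate the contributions of the added ring, its two nitrogen atoms and its methyl group. From the compounds shown here alone, it remains open how a plain phenyl ring, or the same pyrazole without its methyl group, would behave on this carbon.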